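The compounds below may be only part of what the source reports. "The series", "measured", "known", "first", "only" and "open" are said of these compounds alone.

Measured in an ADME assay on J774 cells (Mus musculus) for cytotoxicity (on this read-out lower numbers stand for an effect already at smaller amounts and higher numbers for an effect only at larger amounts of compound), so far:
- compound 1 `CCCCc1cc2c(=O)c(C(=O)OCC)c[nH]c2cc1OCCOc1ccccc1` gives > 20000 nM as a limit
- compound 2 `CCOc1ccc2[nH]cc(C(=O)OC)c(=O)c2c1` gives > 20000 nM as a limit

Going by the values given here, compound 1 has only a limit and no number, and compound 2 is in the same position, so the series so far consists of the limit of > 20000 nM in this assay, at which 2 of the 2 values shown sit, and nothing more. Compound 3 `CCCCc1cc2c(=O)cc[nH]c2cc1OCCOc1ccccc1` has hydrogen in place of ethoxycarbonyl on an aromatic carbon, two atoms from the ring nitrogen (hydrogen in place of ethoxycarbonyl on an aromatic carbon). Among the compounds with values here, no measured pair tests this change. In this assay a step no larger than the usual scatter is expected, and any shift that does appear is expected toward lower numbers. The estimated at least 1.3-fold lower number from compound 1 to compound 3 (0.12 log units; that floor lies within the scatter) is therefore small. For compound 3 the expected value is 15000 nM and the estimated range runs from 5000 nM to 30000 nM in this read-out.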

Compound 3, half-maximal effective concentration: > 20000 nM
Compound 3: a limit, no number; the forecaster's own chance of this, stated with the estimate: 60%; middle value at least 1.3-fold (0.12 log units) away from the limit.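

Compound 1 and compound 3 both stand only as limits in this assay, so no step can be read for hydrogen in place of ethoxycarbonyl: the limit of > 20000 nM in this assay, at which 3 of the 3 values shown sit.

The compounds shown leave open at what concentration compound 1, compound 2 or compound 3 would show an effect in this assay, and whether this exchange changes that concentration.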